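Repeating a Methoxy Step on a Thiosemicarbazone Pair

The source may report more compounds than this note shows. Statements on the series, on what has been measured and on what is new or still open speak of the compounds shown alone.

Compound 1 `CC1=CC[C@H](C(C)(C)NC(=S)N/N=C/c2ccccc2)CC1` and compound 2 `COc1ccc(/C=N/NC(=S)NC(C)(C)[C@H]2CC=C(C)CC2)cc1` share one core and differ in a single place: methoxy in place of hydrogen on an aromatic carbon. In a functional assay on NCI-H460 cells (Homo sapiens) for inhibition, read by sulforhodamine B assay, with a stated time of 48 h (a lower number here means a stronger inhibitor of growth, a higher number a weaker inhibitor of growth), compound 1 gives 53900 nM. In this assay compound 2 gives 47800 nM. The step between them is a 1.1-fold lower number from compound 1 to compound 2 (0.05 log units; within the scatter), so the two numbers cannot be told apart.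

Compound 3 `CC1=CC[C@H](C(C)(C)NC(=S)N/N=C(\C)c2ccccc2)CC1` carries a different core; the difference between the core of compound 3 and the core of compound 1 is not broken down here. In this assay compound 3 returns only a limit of the assay, > 100000 nM. Compound 3 therefore sits at the limit of > 100000 nM in this assay, at which 1 of the 3 values shown sits.

Compound 4 `COc1ccc(/C(C)=N/NC(=S)NC(C)(C)[C@H]2CC=C(C)CC2)cc1` has not yet been measured. It stands to compound 3 exactly as compound 2 stands to compound 1, with the same change at the same place: methoxy in place of hydrogen on an aromatic carbon.

Among the measured compounds shown here, the expectation for compound 4 rests on the one measured instance of this change, where the step of a 1.1-fold lower number from compound 1 to compound 2 (0.05 log units; within the scatter) stayed within the scatter. On that basis the step that the limit leaves unreadable from compound 3 to compound 4 is expected to be small as well. Since compound 3 is known only as a limit, the number for compound 4 is expected to lie near that limit, and a limit may again be all that is reported. Compound 4 is thus estimated at 110000 nM, with a range from 45000 nM to 300000 nM.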

Compound 4, concentration for total growth inhibition: > 100000 nM
Compound 4: no number, only a limit; the forecaster's own chance of this, stated with the estimate: 60%; the middle value is on the limit's open side.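

No new step can be read between compound 3 and compound 4, since this assay reports each of them only as a limit of the assay: the limit of > 100000 nM in this assay, at which 2 of the 4 values shown sit.

The compounds shown leave open whether methoxy in place of hydrogen on an aromatic carbon changes growth inhibition on the core of compound 3 as little as it does on the core of compound 1.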